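Replacing a tert-butyl amide with a thiadiazole amide

A few compounds are considered here, and "the series" means these few. Any claim that something is new, unique, unknown or untested is made for them only; others in the source may bear on it.

Compound 1 `CC(C)[C@H](C(=O)NC(C)(C)C)c1ccc(Cl)cc1` is the tert-butyl amide of the shared core. In a functional assay on CHO cells for agonist activity at Free fatty acid receptor 2 (Homo sapiens), read by cAMP accumulation (on this read-out lower numbers stand for smaller maximal responses and higher numbers for larger maximal responses), compound 1 reaches only a limit of the assay, < 30%. This is the point described by the limit of < 30% in this assay, at which 1 of the 3 values shown sits. Two amides of the same core that carry a heteroaromatic ring have been measured. Compound 2 `CC(C)C(C(=O)Nc1ncccn1)c1ccc(Cl)cc1` gives 50% in this assay. Compound 3 `CC(C)[C@H](C(=O)Nc1nnc(C(F)(F)F)s1)c1ccc(Cl)cc1` gives 115% in this assay. Compound 4 `CC(C)[C@H](C(=O)Nc1cnns1)c1ccc(Cl)cc1` is the next member; it differs from compound 1 by 1,2,3-thiadiazol-5-yl in place of tert-butyl on an amide-type nitrogen.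

Going by the values given here, no step between two measured compounds is available here, so the pair of compound 1 and compound 4 can be judged only from what the other amides show. Compound 2 gives 50% and compound 3 gives 115% in this assay, both of them sizeable responses. On that basis a large upward step, beyond the scatter, is expected for a number at least 50 percentage points higher from compound 1 to compound 4 (beyond the scatter) in this assay. Compound 4 is expected to give an efficacy of about 80%, with a range from 45% to 115%.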

Compound 4, largest response reached (reported as efficacy), in percent of the reference or control that the assay uses: 48%
The estimate for compound 4 lay 32 percentage points above the measured number; measured number inside the range.
By their numbers in this assay, from the lowest: compounds 4 and 2 (each within the scatter of the next); then compound 3. At a limit, below all of these: compound 1.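

In this assay, 1,2,3-thiadiazol-5-yl in place of tert-butyl on an amide-type nitrogen gives a number at least 18 percentage points higher from compound 1 to compound 4 (beyond the scatter), so this position tolerates a change from a branched carbon group to a five-membered aromatic ring with a gain in maximal response. That step can be stated only as a minimum because the value for compound 1 is a limit of the assay, not a number: the limit of < 30% in this assay, at which 1 of the 4 values shown sits. A thiadiazole amide alone does not reach the response of compound 3, since compound 4 gives 48% in this assay whereas compound 3 gives 115%.

From the compounds shown here alone, whether a methyl group or an amine on the ring of compound 4 would bring its response closer to that of compound 3 remains open. So does how a plain phenyl ring on the amide nitrogen would compare.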